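This account rests on a few compounds, and the source may have more. Where it says the series, first, only, none or still open, it means among the compounds named here.

Compound 1 `C=CC(=C)CC[C@@H]1[C@@]2(C)CCC[C@](C)(COC(=O)/C=C\c3ccc(O)cc3)[C@@H]2CC[C@@]1(C)O` is the starting point. Among the compounds with values here, in a functional assay on SW480 cells (Homo sapiens) for cytotoxicity, read by MTT assay, with a stated time of 48 h (on this read-out higher numbers stand for weaker inhibition and lower numbers for stronger inhibition), compound 1 gives 13600 nM, the only plain number among the two values shown. Compound 2 `C=C1CC[C@@H]2[C@](C)(CCC[C@]2(C)C(=O)O)[C@H]1C/C=C(\C)C=O` stands apart from it. In this assay compound 2 gives > 40000 nM, which is a limit of the assay rather than a number. That is the limit of > 40000 nM in this assay, at which 1 of the 2 values shown sits. Compound 1 and compound 2 differ in many places at once. Within the data shown here, no single step between them can be read from these two values.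

Compound 3 `C=CC(=C)CC[C@@H]1[C@@]2(C)CCC[C@](C)(COC(=O)/C=C\c3ccc(O)c(OC)c3)[C@@H]2CC[C@@]1(C)O` is not yet measured. It differs from compound 1 in one place: methoxy in place of hydrogen on an aromatic carbon. The methoxy group enters on the six-membered aromatic ring of carbon only, ortho to a hydroxy group. Among the measured compounds shown here, no measured pair shows what such a change does here, so the expectation rests on compound 1 alone. In this assay the expected step is modest, a 1.1-fold lower number from compound 1 to compound 3 (0.05 log units; within the scatter), and in neither direction clearly beyond the scatter of repeated measurements. Compound 3 is therefore expected to give about 12000 nM, with a likely range from 5000 nM to 35000 nM.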

Compound 3, half-maximal inhibitory concentration: 17600 nM
Compound 3: middle estimate off by 1.5-fold (0.17 log units), on the low side, within the range that was stated.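

Placing a methoxy group in this spot, on the aromatic ring and ortho to a hydroxy group, gives the first measured change in a single place, and in this assay it amounts to a 1.3-fold higher number from compound 1 to compound 3 (0.11 log units; within the scatter). The position therefore tolerates a methoxy group in place of hydrogen: compound 1 and compound 3 read the same within the usual scatter, even though two heavy atoms enter the molecule. Nothing measured here gives a reason for this result.

On these data alone, one step at one position says little about what other groups would do, so it stays open whether ethoxy, chlorine or an amine in this same place would move the number beyond the scatter, and whether a methoxy group in place of the hydroxy group itself would do so. Also open, as far as these compounds go, is the rest of the molecule, where the ester joining the aromatic part to the shared core could give way to an amide, and where changes to the core itself remain to be read one at a time.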